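The source may hold more compounds than are shown below. What is called first, only, known or untested is meant among the compounds shown, and "the series" means these compounds.

Measured compounds in an assay for inhibition of Amine oxidase [flavin-containing] B (Bos taurus), read by fluorescence, with a stated time of 60 min; on this read-out lower numbers stand for stronger inhibition and higher numbers for weaker inhibition:
compound 1, `O=C(NNc1nc2ccccc2nc1Cc1ccccc1)c1ccccc1`, 360000 nM
compound 2, `O=C(NNc1nc2ccccc2nc1Cc1ccccc1)c1ccc(Br)cc1`, 980000 nM
compound 3, `O=C(Cn1c(=O)c(Cc2ccccc2)nc2ccccc21)NNC(=O)c1ccc(Cl)cc1`, 880000 nM

Compound 3 stands second highest of the three numbers in this assay. Its value and that of compound 2 lie within the scatter of each other, so no order between them is claimed; the value of compound 1 is lower than that of compound 3 by a margin beyond the scatter. All three numbers sit at the weak end of the read-out.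

Compound 4, `O=C(Cn1c(=O)c(Cc2ccccc2)nc2ccccc21)N/N=C1/C(=O)Nc2ccccc21`, is not yet measured. It differs from compound 3 as follows: a group of 11 heavy atoms (8 carbon, 2 nitrogen, 1 oxygen; one five-membered non-aromatic ring with 1 hetero atom, one six-membered aromatic ring of carbon only) in place of a group of 10 heavy atoms (7 carbon, 1 nitrogen, 1 oxygen, 1 chlorine; one six-membered aromatic ring of carbon only), on an amide-type nitrogen. Among the measured compounds shown here, the one measured step, a 2.7-fold higher number from compound 1 to compound 2 (0.43 log units; beyond the scatter), is a change of a single substituent on an aromatic carbon within a different core, and therefore has no direct bearing on an exchange of a whole group on the amide-type nitrogen. For the measured compounds named here, no measured pair shows what this exchange does. With nothing to point in either direction, no step beyond the scatter is expected, and the estimate is kept near the value of compound 3. Compound 4 is therefore expected at 600000 nM, with a range of 150000 nM to 2500000 nM, which corresponds to an expected step of a 1.5-fold lower number from compound 3 to compound 4 (0.17 log units; within the scatter). Given how weak the whole series is, there is a fair chance that the read-out returns only a limit.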

Compound 4, half-maximal inhibitory concentration: 96000 nM
Compound 4: the middle estimate sits 6.3-fold (0.80 log units) above what was measured, outside the stated range (below it).
By their numbers in this assay, from the lowest: compound 4; then compound 1; then compounds 3 and 2 (each within the scatter of the next).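

In this assay, the group on the amide-type nitrogen proves able to shift the read-out: exchanging ((4-chlorophenyl)carbonyl)amino for the group with one five-membered non-aromatic ring with 1 hetero atom gives a 9.2-fold lower number from compound 3 to compound 4 (0.96 log units; beyond the scatter). This whole-group exchange is the only change shown at this position, and compound 4, at 96000 nM, still sits toward the weak end of the read-out. No available evidence bears on what lies behind this step.

A single pair cannot separate the contributions of the entering ring system, its double bonds and hydrogen-bond acceptors, or the loss of the chlorine. Also open, going by these compounds, is whether a bromo on the aromatic ring of the entering group, or a simple amine or carboxylic acid at this position, would keep the lower number.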